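Thiophene substituent swap at the para position of the series

This account rests on a few compounds, and the source may have more. Where it says the series, first, only, none or still open, it means among the compounds named here.

Compound 1 `CCC(c1ccc(-c2cscc2C)cc1)n1ccnc1` gives 84% in an assay for inhibition of steroid 17-alpha-hydroxylase/17,20 lyase (Homo sapiens), using NADPH, tested at 2 uM (on this read-out lower numbers stand for a weaker effect and higher numbers for a stronger effect at the one concentration tested), the highest of the three numbers recorded; compound 2 `Cc1cscc1-c1ccc(Cn2ccnc2)cc1` gives 27% and compound 3 `c1ccc(-c2ccc(Cn3ccnc3)cn2)cc1` gives 4%. Among the measured compounds shown here, the only single-place step measured is a number 57 percentage points lower from compound 1 to compound 2 (beyond the scatter), and it concerns the ethyl group, not the thiophene ring. Compound 4 `CCC(c1ccc(-c2ccsc2Cl)cc1)n1ccnc1` differs from compound 1 by 2-chlorothiophen-3-yl in place of 4-methylthiophen-3-yl on an aromatic carbon. For the measured compounds named here, no measured step covers a change on the thiophene ring; compounds 2 and 3 differ from each other in more than one place, so their values show only that both lie far under compound 1. With nothing directly comparable, the step of a number 8 percentage points lower from compound 1 to compound 4 (within the scatter) is expected to fall within or near the scatter. The estimate for compound 4 is 76%, in the range 50% to 92%.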

Compound 4, a percentage reported as inhibition, at one concentration (the size of the read-out at that concentration, not a potency): 85%
Compound 4: the middle estimate sits 9 percentage points below what was measured; low and high end bracket the measured number.
By their numbers in this assay, from the lowest: compound 3; then compound 2; then compounds 1 and 4 (each within the scatter of the next).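

On the aromatic carbon para to a group of 8 heavy atoms, 2-chlorothiophen-3-yl in place of 4-methylthiophen-3-yl gives a number 1 percentage points higher from compound 1 to compound 4 (within the scatter). Among the compounds shown here, this is the first measured step on the thiophene ring, and with the ethyl group kept, the position tolerates this swap. No evidence bears on this result.

As far as these compounds go, whether the same swap holds on compound 2, which lacks the ethyl group, stays open. Also open, from the compounds shown here alone, is how an amine or a carboxylic acid on the thiophene ring would read in this assay.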